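This account rests on a few compounds, and the source may have more. Where it says the series, first, only, none or still open, it means among the compounds named here.

In a functional assay on PC-3 cells (Homo sapiens) for cytotoxicity, read by MTT assay, with a stated time of 24 h (a higher number here means a weaker inhibitor, a lower number a stronger inhibitor), compound 1 `C=C1C(=O)[C@@]23C[C@@H]1CC[C@@H]2[C@@]1(C)CCCC(C)(C)[C@@H]1COC3=O` gives 11500 nM as a measured number. Compound 2 `C=C1CC[C@H](C)[C@@](C)(CCC2=CC(OCC)OC2=O)C/C=C\C=C/1C(=O)O` reads > 40000 nM as a limit of the assay and not a number. Compound 3 `C[C@H]1CC[C@@]2(C)C(C(=O)O)=CCC[C@H]2[C@]1(C)CCC1=CCOC1=O` reads > 40000 nM as a limit too. Compound 2 thus stands at the limit of > 40000 nM in this assay, at which 2 of the 3 values shown sit, and no closer figure is known for it. From compound 2 to compound 4 `C=C1CC[C@H](C)[C@@](C)(CCC2=CCOC2=O)C/C=C\C=C/1C(=O)O` the change is hydrogen in place of ethoxy on a saturated ring carbon with hydrogen in place of ethoxy on a saturated ring carbon, next to the ring oxygen. Compound 3 also has no ethoxy there and reads > 40000 nM as a limit, so no step beyond the scatter is expected in this assay in either direction. The estimated a number no higher from compound 2 to compound 4 (the limit leaves the size open) is expected to stay inside that scatter. For compound 4 the estimated value is 40000 nM with an expected range from 20000 nM to 80000 nM in this estimate.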

Compound 4, half-maximal inhibitory concentration: > 40000 nM
Compound 4 ended at the assay's limit (the forecaster's own chance of this, stated with the estimate: 80%); the middle value lies on the limit itself.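

Compound 2 and compound 4 both read as limits of the assay and not as numbers, so no step can be read between them: the limit of > 40000 nM in this assay, at which 3 of the 4 values shown sit.

The compounds shown leave open whether hydrogen in place of ethoxy changes the activity at all.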